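Aryl exchange on the fused core: compound 2 to compound 3

The compounds below may be only part of what the source reports. "The series", "measured", "known", "first", "only" and "open" are said of these compounds alone.

Measured so far:
compound 1 `COc1ccc(-c2cccc3c2N(S(=O)(=O)c2ccc(OC)cc2)CC3)cc1` — 277 nM
compound 2 `COc1ccc(S(=O)(=O)N2CCc3cccc(-c4ccncc4)c32)cc1` — 87.5 nM

Going by the values given here, in a functional assay on HT-29 cells (Homo sapiens) for inhibition, with a stated time of 72 h (a lower number here means a stronger inhibitor, a higher number a weaker inhibitor), compound 2 stands at the lowest of the two numbers; compound 1 gives 277 nM in this assay, and the only measured step, a 3.2-fold lower number from compound 1 to compound 2 (0.50 log units; beyond the scatter), is the sole guide here. Compound 3 `COc1ccc(S(=O)(=O)N2CCc3cccc(-c4cccs4)c32)cc1` carries thiophen-2-yl in place of pyridin-4-yl on an aromatic carbon. Among the compounds with values here, no measured step involves thiophen-2-yl, so the expectation leans on that single step alone: a modest move back toward the number of compound 1 is expected, beyond the scatter. Compound 3 is therefore estimated at 200 nM in this assay, with a range of 70 nM to 600 nM. This expected shift amounts to a 2.3-fold higher number from compound 2 to compound 3 (0.36 log units; beyond the scatter).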

Compound 3, half-maximal inhibitory concentration: 200 nM
Compound 3: middle estimate and measured number agree at the digits printed, and the stated range covers the measured number.
By their numbers in this assay, from the lowest: compound 2; then compounds 3 and 1 (each within the scatter of the next).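

On this aromatic carbon of the shared core, this assay separates thiophen-2-yl from pyridin-4-yl, with a 2.3-fold higher number from compound 2 to compound 3 (0.36 log units; beyond the scatter). Set against 4-methoxyphenyl, thiophen-2-yl gives a 1.4-fold lower number from compound 1 to compound 3 (0.14 log units; within the scatter), so a five-membered aromatic ring and the 4-methoxyphenyl group cannot be told apart here, and of the three groups only pyridin-4-yl stands apart. No available data bear on the reason for this difference. Still open, going by these compounds, is whether pyridin-3-yl or a saturated amine such as piperazine at this carbon would match or pass compound 2.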